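Ring replacement on compound 2: clearance expectation

A few compounds are considered here, and "the series" means these few. Any claim that something is new, unique, unknown or untested is made for them only; others in the source may bear on it.

Measured so far:
compound 1 `Cc1cc(C)c(-c2c[nH]nc2C)cc1NC(=O)c1ccc(OCc2ccccn2)cc1` gives 20 mL.min-1.g-1
compound 2 `Cc1cc(C)c(-c2c(C)nn(C)c2C)cc1NC(=O)c1ccc(OCc2ccccn2)cc1` gives 122 mL.min-1.g-1

Within the data shown here, in an ADME assay on microsomes from liver (Homo sapiens) for metabolic stability (a lower number here means slower removal, a higher number faster removal of the compound), compound 2 stands highest of the two numbers measured; the only step known, a 6.1-fold higher number from compound 1 to compound 2 (0.79 log units; beyond the scatter), separates it from compound 1.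

Compound 3 `Cc1cc(C)c(-c2ccc(N)cn2)cc1NC(=O)c1ccc(OCc2ccccn2)cc1` differs from compound 2 in one place: 5-aminopyridin-2-yl in place of 1,3,5-trimethyl-1H-pyrazol-4-yl on an aromatic carbon. Among the measured compounds shown here, the sole step available, a 6.1-fold higher number from compound 1 to compound 2 (0.79 log units; beyond the scatter), bears on this change only loosely, as it concerns a different pair of groups at the same position. A lower number than compound 2 is expected for compound 3, a step of roughly a 3.5-fold lower number from compound 2 to compound 3 (0.54 log units; beyond the scatter). Compound 3 is estimated at 35 mL.min-1.g-1, within 12 mL.min-1.g-1 to 100 mL.min-1.g-1.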

Compound 3, intrinsic clearance in microsomes: 9 mL.min-1.g-1
Compound 3: middle estimate off by 3.9-fold (0.59 log units), on the high side; measured number below the stated range.
By their numbers in this assay, from the lowest: compound 3; then compound 1; then compound 2.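

In this assay, a six-membered aromatic ring at this position, 5-aminopyridin-2-yl, gives the lowest number of the three, a step of a 14-fold lower number from compound 2 to compound 3 (1.13 log units; beyond the scatter) and still one a 2.2-fold lower number from compound 1 to compound 3 (0.35 log units; beyond the scatter) beyond the scatter. The earlier compounds shown here showed only a change between substituted pyrazoles; this position also accepts a change of ring that takes the number below both. Nothing available bears on the cause of these steps. As far as these compounds go, the ring and the amine change together here, so their separate shares stay open. A plain pyridin-2-yl, or a methoxy group in place of the amine, would separate them.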